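The source may report more compounds than this note shows. Statements on the series, on what has been measured and on what is new or still open speak of the compounds shown alone.

Measured compounds and their values:
Compound 1, `Brc1cn2ccnc2c(-c2ccc3ncn(C4CCCCC4)c3c2)n1`, 47.6%
Compound 2, `O=Cc1ccc(-c2cn3ccnc3c(-c3ccc4ncn(C5CCCCC5)c4c3)n2)cc1`, 47.8%

The two measured compounds share one core and differ only in the group carried on an aromatic carbon of that core. In a functional assay on MCF7 cells (Homo sapiens) for inhibition, read by sulforhodamine B assay, with a stated time of 48 h, tested at 10 uM (on this read-out higher numbers stand for more inhibition at the one concentration tested (going by the name of the read-out) and lower numbers for less inhibition), compound 1 gives 47.6%, and in this assay compound 2 gives 47.8%. Among the compounds with values here, the one measured step, a number 0.2 percentage points higher from compound 1 to compound 2 (within the scatter), lies within the scatter, so the two numbers cannot be told apart; compound 2 stands at the higher of the two only in the bare figures, with compound 1 indistinguishable from it.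

Compound 3, `c1ccc2c(-c3cn4ccnc4c(-c4ccc5ncn(C6CCCCC6)c5c4)n3)cccc2c1`, has not yet been measured. It differs from compound 2 in one place: naphthalen-1-yl in place of 4-formylphenyl on an aromatic carbon. Within the data shown here, the only step that bears on this change is a number 0.2 percentage points higher from compound 1 to compound 2 (within the scatter), where exchanging bromo for 4-formylphenyl at the same carbon left the read-out unchanged. The aryl group is now exchanged for a larger one. On this basis no step beyond the scatter is expected; the estimated step is a number 1.8 percentage points lower from compound 2 to compound 3 (within the scatter). Compound 3 is thus expected to give about 46%, with a range from 26% to 66%.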

Compound 3, a percentage reported as inhibition, at one concentration (the size of the read-out at that concentration, not a potency): 13%
Beside the measured number, compound 3's estimate is 33 percentage points above it, outside the stated range (below it).
By their numbers in this assay, from the lowest: compound 3; then compounds 1 and 2 (each within the scatter of the next).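

In this assay the aromatic carbon that carries the varied group turns out not to be indifferent to what sits there. Naphthalen-1-yl in place of 4-formylphenyl brings a number 34.8 percentage points lower from compound 2 to compound 3 (beyond the scatter) and in place of bromo brings a number 34.6 percentage points lower from compound 1 to compound 3 (beyond the scatter) at the same carbon, whereas the earlier exchange of bromo for 4-formylphenyl gave no step that could be told from the scatter. The number therefore stays level across two very different groups at this position, yet the read-out falls sharply with naphthalen-1-yl, which brings two six-membered aromatic rings of carbon only; nothing at hand explains this fall.

The compounds shown leave open whether the lower number goes with the second fused ring as such or with the way it is attached, a question that naphthalen-2-yl or a plain phenyl at this carbon would bear on. They also leave open how single-ring groups carrying something other than the formyl group, such as 4-aminophenyl or 4-carboxyphenyl, would read here, and whether any group at this carbon can raise the number above that of compound 1 and compound 2.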